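The source may report more compounds than this note shows. Statements on the series, on what has been measured and on what is new or still open speak of the compounds shown alone.

Of the compounds shown here, three have been measured in an assay for inhibition of kynurenine 3-monooxygenase (Rattus norvegicus); a lower number here means a stronger inhibitor, a higher number a weaker inhibitor. Compound 1 `COC(=O)C(=O)/C=C(\O)c1cccc(Cl)c1` gives 1900 nM, compound 2 `COC(=O)C(=O)/C=C(\O)c1cccc(F)c1` gives 1600 nM, and compound 3 `COC(=O)C(=O)/C=C(\O)c1cccc(F)c1F` gives 8100 nM. Compound 2 has the lowest of these numbers, but compound 1 sits within the scatter of it, so the two cannot be told apart; only compound 3 stands clearly higher. Two single changes link the three: a 1.2-fold lower number from compound 1 to compound 2 (0.07 log units; within the scatter), and a 5.1-fold higher number from compound 2 to compound 3 (0.70 log units; beyond the scatter).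

Compound 4 `COC(=O)C(=O)/C=C(\O)c1ccc(F)c(F)c1` has not yet been measured. It differs from compound 2 in one place: fluoro in place of hydrogen on an aromatic carbon. The step from compound 2 to compound 3 is the one that bears on this change: it too put a fluoro in place of a hydrogen ortho to the fluoro already present, though on a different carbon of the same ring, and it moved the number in this assay by a modest amount. A second fluoro on a different carbon need not do the same, but nothing measured here points the other way. Compound 4 is therefore expected to show a 2.5-fold higher number from compound 2 to compound 4 (0.40 log units; beyond the scatter), a rise of roughly the same size or somewhat smaller. The estimate for compound 4 in this assay is 4000 nM, with a likely range from 1600 nM to 10000 nM.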

Compound 4, half-maximal inhibitory concentration: 3300 nM
Beside the measured number, compound 4's estimate is 1.2-fold (0.08 log units) above it; low and high end bracket the measured number.
By their numbers in this assay, from the lowest: compounds 2, 1 and 4 (each within the scatter of the next, the first and the last beyond it); then compound 3.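

The result in this assay gives this position a reading of its own: there is a 2.1-fold higher number from compound 2 to compound 4 (0.31 log units; beyond the scatter) when a fluoro replaces hydrogen on the carbon ortho to the fluoro already present and para to the group of 9 heavy atoms. The step is modest but beyond the scatter, so this added fluoro does not leave the number unchanged. Alongside a 5.1-fold higher number from compound 2 to compound 3 (0.70 log units; beyond the scatter) on a different carbon of the same ring, it means that both fluoro additions to compound 2 shown here raise the number, and neither goes against that pattern. No measurement shown here explains why the number rises at this position.

The compounds shown leave open whether the rise belongs to fluoro in particular or would also follow from another group on this carbon, such as a methyl, a methoxy or an amine. They also leave open whether a larger group here, such as a longer chain, would raise the number further, leave it within the scatter of compound 2 or lower it.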